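The source may report more compounds than this note shows. Statements on the series, on what has been measured and on what is new or still open speak of the compounds shown alone.

Of the compounds shown here, three sharing one core have been measured in an assay on mitochondria from L6 cells (Rattus norvegicus) for activation, with a stated time of 90 min; on this read-out higher numbers stand for an effect only at larger amounts of compound and lower numbers for an effect already at smaller amounts. Compound 1 `CCCCOc1ccc(Nc2nc3nonc3nc2O)cc1` gives 3700 nM in this assay, compound 2 `CC(C)(C)c1ccc(Nc2nc3nonc3nc2O)cc1` gives 3900 nM, and compound 3 `CCCCCc1ccc(Nc2nc3nonc3nc2O)cc1` gives 2400 nM. The three numbers lie close together: a 1.1-fold higher number from compound 1 to compound 2 (0.02 log units; within the scatter), a 1.5-fold lower number from compound 1 to compound 3 (0.19 log units; within the scatter) and a 1.6-fold lower number from compound 2 to compound 3 (0.21 log units; within the scatter) are all small. Compound 3 thus has the lowest of the three numbers, but its gaps to compound 1 and to compound 2 are within the scatter, so no order among the three is secure.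

Compound 4 `CC(=O)c1ccc(Nc2nc3nonc3nc2O)cc1` is the next step from compound 3: acetyl in place of pentyl on an aromatic carbon. The measured steps that bear on this are the exchanges at the same position among butoxy, tert-butyl and pentyl, and none of them moved the number beyond the scatter. Acetyl, though, carries a hydrogen-bond acceptor and a double bond outside aromatic rings, and no measured pair shows what such a change does on this core. The expected step is therefore a 1.9-fold higher number from compound 3 to compound 4 (0.27 log units; within the scatter) in this assay, close to no change but with wide uncertainty. Compound 4 is expected to give an estimated 4500 nM in this assay, with a range from 1500 nM to 13000 nM.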

Compound 4, half-maximal effective concentration: 93700 nM
Beside the measured number, compound 4's estimate is 21-fold (1.32 log units) below it, outside the stated range (above it).
By their numbers in this assay, from the lowest: compounds 3, 1 and 2 (each within the scatter of the next); then compound 4.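

Within the data shown here, the position on the six-membered aromatic ring, where butoxy, tert-butyl and pentyl were exchanged with no step beyond the scatter, does respond to the group it carries: in this assay, acetyl in place of pentyl gives a 39-fold higher number from compound 3 to compound 4 (1.59 log units; beyond the scatter) and is the first large step on this core. The picture is the same against the other two groups, with acetyl in place of tert-butyl giving a 24-fold higher number from compound 2 to compound 4 (1.38 log units; beyond the scatter) and acetyl in place of butoxy giving a 25-fold higher number from compound 1 to compound 4 (1.40 log units; beyond the scatter), so an effect only at much larger amounts goes with acetyl, whichever of the three groups it replaces. Acetyl has fewer heavy atoms than pentyl and adds a double bond outside aromatic rings and a hydrogen-bond acceptor, but no measurement available here links the jump to any of these differences.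

The compounds shown cannot separate the carbonyl from the shorter group, so a ketone on a longer chain at this place would be informative. Going by these compounds, how a nitrile, an amide or a carboxylic acid at the same place would compare with acetyl on the shared core also remains open.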